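Swapping the methylpiperazine chain for a dihydroxypropyl triazole

The compounds below may be only part of what the source reports. "The series", "measured", "known", "first", "only" and "open" are said of these compounds alone.

Of the compounds shown here, three built on one shared core have been tested in a functional assay on MDA-MB-231 cells (Homo sapiens) for cytotoxicity, read by MTT assay, with a stated time of 72 h; on this read-out lower numbers stand for stronger inhibition and higher numbers for weaker inhibition. There compound 1 `O=C1c2c[n+]([O-])c3ccccc3c2C(=O)c2c1c1ccccc1n2Cc1cn([C@H]2O[C@H](CO)[C@@H](O)[C@H]2O)nn1` gives 1700 nM, compound 2 `O=C1c2c[n+]([O-])c3ccccc3c2C(=O)c2c1c1ccccc1n2CCN1CCCC1` gives 630 nM and compound 3 `CN1CCN(CCCn2c3c(c4ccccc42)C(=O)c2c[n+]([O-])c4ccccc4c2C3=O)CC1` gives 390 nM. Compound 3 thus stands at the low end of these numbers, level within the scatter with compound 2 and beyond the scatter from compound 1.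

Compound 4 `O=C1c2c[n+]([O-])c3ccccc3c2C(=O)c2c1c1ccccc1n2Cc1cn(C[C@@H](O)CO)nn1` has not yet been measured. Its difference from compound 3 is this: 1-(2,3-dihydroxypropyl)-1H-1,2,3-triazol-4-yl in place of 2-(4-methylpiperazin-1-yl)ethyl on a saturated chain carbon bound to an aromatic nitrogen. Cut one bond further out, the same difference reads 3-(4-methylpiperazin-1-yl)propyl to (1-(2,3-dihydroxypropyl)-1H-1,2,3-triazol-4-yl)methyl.

Among the compounds with values here, only one measured step is available, a 1.6-fold lower number from compound 2 to compound 3 (0.21 log units; within the scatter). It stays within the scatter and exchanges pyrrolidin-1-yl for (4-methylpiperazin-1-yl)methyl, so it says little about a triazole entering. Within the data shown here, the nearer guide is compound 1, which also carries a triazole in its side chain and gives 1700 nM, although no measured step links it directly to compound 3. A move to a higher number is therefore expected, an estimated 3.6-fold higher number from compound 3 to compound 4 (0.56 log units; beyond the scatter) in this assay. The estimated value for compound 4 is 1400 nM, with an expected range from 600 nM to 3200 nM.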

Compound 4, half-maximal inhibitory concentration: 670 nM
Compound 4: middle estimate off by 2.1-fold (0.32 log units), on the high side, within the range that was stated.
By their numbers in this assay, from the lowest: compounds 3, 2 and 4 (each within the scatter of the next); then compound 1.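

In this assay, the step of a 1.7-fold higher number from compound 3 to compound 4 (0.24 log units; within the scatter) shows that, on a saturated chain carbon bound to an aromatic nitrogen, 1-(2,3-dihydroxypropyl)-1H-1,2,3-triazol-4-yl can take the place of 2-(4-methylpiperazin-1-yl)ethyl with the values staying within the scatter. Within the data shown here, the step of a 1.1-fold higher number from compound 2 to compound 4 (0.03 log units; within the scatter) shows the same for the exchange with (pyrrolidin-1-yl)methyl, so at this position a triazole side chain with two hydrogen-bond donors stands level with both amine chains, which the earlier compounds could not show. The step of a 2.5-fold lower number from compound 1 to compound 4 (0.40 log units; beyond the scatter), modest but beyond the scatter, separates two triazole side chains and ties the gap to one exchange on an aromatic nitrogen, 2,3-dihydroxypropyl in place of 3,4-dihydroxy-5-(hydroxymethyl)oxolan-2-yl. Nothing available explains these steps.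

The compounds shown leave open how much of this level result belongs to the triazole and how much to the 2,3-dihydroxypropyl group on it, which a simple methyl, a carboxylic acid or a longer chain on the triazole could test. The opposite configuration at the defined stereocentre of the diol also remains an open question.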